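Replacing the terminal dimethylamino with propyl on the piperazine chain

The source may report more compounds than this note shows. Statements on the series, on what has been measured and on what is new or still open speak of the compounds shown alone.

Measured compounds:
compound 1 `Cc1cccc2sc(NC(=O)CCN3CCN(CCN(C)C)CC3)nc12` gives 1000 nM
compound 2 `Cc1cccc2sc(NC(=O)CCN3CCN(CCCN(C)C)CC3)nc12` gives 570 nM

Of the compounds shown here, two have been measured in an assay on membranes from brain for displacement of a labelled ligand from Sigma non-opioid intracellular receptor 1 (Cavia porcellus), read by scintillation counting, with a stated time of 120 min; on this read-out lower numbers stand for stronger inhibition and higher numbers for weaker inhibition. Compound 1 `Cc1cccc2sc(NC(=O)CCN3CCN(CCN(C)C)CC3)nc12` gives 1000 nM. For the measured compounds named here, compound 2 `Cc1cccc2sc(NC(=O)CCN3CCN(CCCN(C)C)CC3)nc12` gives 570 nM, the lower of the two numbers, but the only step measured, a 1.8-fold lower number from compound 1 to compound 2 (0.24 log units; within the scatter), lies within the scatter, so the two compounds cannot be separated on these data.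

Compound 3 `CCCCCCN1CCN(CCC(=O)Nc2nc3c(C)cccc3s2)CC1` is not yet measured. It differs from compound 2 by propyl in place of dimethylamino on a saturated chain carbon, three bonds along the chain from an amine nitrogen in a ring. Going by the values given here, no measured step bears on this change: the only step known, a 1.8-fold lower number from compound 1 to compound 2 (0.24 log units; within the scatter), concerns lengthening the chain that carries the dimethylamino, not its removal, and it was itself within the scatter. The data therefore give no basis to expect a step beyond the scatter in either direction, though the change in kind leaves the outcome open. The expected step is a 1.3-fold lower number from compound 2 to compound 3 (0.10 log units; within the scatter), within the scatter. Compound 3 is estimated to give 450 nM, with a range of 120 nM to 1700 nM.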

Compound 3, inhibition constant: 238 nM
The estimate for compound 3 lay 1.9-fold (0.28 log units) above the measured number; the measured number falls inside the stated range.
By their numbers in this assay, from the lowest: compound 3; then compounds 2 and 1 (each within the scatter of the next).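

In this assay the terminal dimethylamino proves dispensable at this position: an all-carbon propyl in its place, three bonds along the chain from the ring amine nitrogen, gives a 2.4-fold lower number from compound 2 to compound 3 (0.38 log units; beyond the scatter) and so produces a change that the earlier pair, which stayed within the scatter, could not show. The same holds against the shorter amine chain, where the change to the hexyl chain of compound 3 gives a 4.2-fold lower number from compound 1 to compound 3 (0.62 log units; beyond the scatter) and places compound 3 lowest of the three, with both of its steps beyond the scatter while compound 1 and compound 2 remain inseparable. No measured finding is available to account for these steps.

The compounds shown leave open whether a longer alkyl chain such as octyl or a shorter one such as butyl would move the number further, and so whether hexyl lies near a best length or merely on a continuing trend. They also leave open whether a chain ending in a hydroxyl, a methoxy or a phenyl group would behave like hexyl or like the dimethylamino chains.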